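Removing the methyl from compound 2's aryl triazole

This account rests on a few compounds, and the source may have more. Where it says the series, first, only, none or still open, it means among the compounds named here.

Compound 2 `Cc1ccc(-c2cn(C/C=C3\OC(=O)C(OCc4ccccc4)=C3OCc3ccccc3)nn2)cc1` stands in a functional assay on MDA-MB-231 cells (Homo sapiens) for antiproliferative activity, read by MTT assay, with a stated time of 24 h (a higher number here means a weaker inhibitor, a lower number a stronger inhibitor), only at a limit: compound 2 gives > 100000 nM, which is a limit of the assay rather than a number (the limit of > 100000 nM in this assay, at which 1 of the 2 values shown sits). Among the measured compounds shown here, its one measured neighbour, compound 1 `O=C1O/C(=C\Cn2cc(Cc3ccccc3)nn2)C(OCc2ccccc2)=C1OCc1ccccc1`, gives 29200 nM in this assay, and the single measured step is an at least 3.4-fold higher number from compound 1 to compound 2 (0.53 log units; beyond the scatter). Compound 3 `O=C1O/C(=C\Cn2cc(-c3ccccc3)nn2)C(OCc2ccccc2)=C1OCc1ccccc1` differs from compound 2 by hydrogen in place of methyl on an aromatic carbon. For the measured compounds named here, no measured step covers this change, and the step from compound 1 replaces the whole benzyl, so no shift beyond the scatter in this assay is expected. Compound 3 is estimated at 90000 nM, between 30000 nM and 250000 nM, a step of an at least 1.1-fold lower number from compound 2 to compound 3 (0.04 log units; that floor lies within the scatter).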

Compound 3, half-maximal inhibitory concentration: 44000 nM
For compound 3 the middle estimate is 2.0-fold (0.31 log units) above the measured one; low and high end bracket the measured number.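

In this assay, hydrogen in place of methyl gives an at least 2.2-fold lower number from compound 2 to compound 3 (0.35 log units; beyond the scatter), so this single methyl on the phenyl ring makes a difference beyond the scatter. Phenyl in place of benzyl gives a 1.5-fold higher number from compound 1 to compound 3 (0.18 log units; within the scatter), so that exchange alone shifts nothing beyond the scatter, and the step from compound 1 to compound 2 is better traced to the methyl. The size of the methyl step is only a floor, since compound 2 stands at a limit of the assay: the limit of > 100000 nM in this assay, at which 1 of the 3 values shown sits. The compounds shown leave open how a methoxy group, a chlorine atom or an amine at this place on the phenyl ring would read.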